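The source may hold more compounds than are shown below. What is called first, only, known or untested is meant among the compounds shown, and "the series" means these compounds.

Notes on the series in a functional assay on MCF7 cells (Homo sapiens) for cytotoxicity, read by MTT assay, with a stated time of 72 h; on this read-out lower numbers stand for stronger inhibition and higher numbers for weaker inhibition.

Compound 1 `O=c1cc(CSc2nc3ccccc3s2)oc2ccccc12` is the parent of the set. In this assay compound 1 gives only the limit of the assay, > 25000 nM. Compound 2 `O=c1cc(CSc2nc3ccccc3s2)oc2ccc(Cl)cc12` carries chloro in place of hydrogen on an aromatic carbon of the parent. In this assay compound 2 likewise gives only the limit, > 25000 nM. Compound 3 `Nc1nnc(SCc2cc(=O)c3ccccc3o2)s1` is a further member of the set. In this assay compound 3 also gives only the limit, > 25000 nM.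

The step that the two limits leave unreadable from compound 1 to compound 2 cannot be read, since both of its ends are limits. For the measured compounds named here, all values shown sit at the same limit, (the limit of > 25000 nM in this assay, at which 3 of the 3 values shown sit), so no measured step has a readable size. Compound 2 therefore stands where every measured compound stands: at the limit, without a number.

Compound 4 `Cc1ccc2oc(CSc3nc4ccccc4s3)cc(=O)c2c1` follows from compound 2 by methyl in place of chloro on an aromatic carbon. Going by the values given here, no measured step bears on this change in a readable way; the only step between measured compounds, a step that the two limits leave unreadable from compound 1 to compound 2, is unreadable. For compound 4 the expected step is a step that the limit leaves unreadable from compound 2 to compound 4, none beyond the scatter. Compound 4 is expected to give 30000 nM in this assay, within 10000 nM to 100000 nM, most likely reported again only as a limit.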

Compound 4, half-maximal inhibitory concentration: > 25000 nM
Compound 4 was reported as a limit; the forecaster's own chance of this, stated with the estimate: 85%; the middle value lies beyond the limit too.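

Compound 4 adds no readable step from compound 1 or compound 2 in this assay, since both ends of each change are limits, and the series stays at a single limit: the limit of > 25000 nM in this assay, at which 4 of the 4 values shown sit.

The compounds shown leave open whether any change to the shared core gives a measurable value in this assay, and how hydrogen, chloro and methyl on that aromatic carbon rank.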